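Amide-end ring change, read against two limits

This account rests on a few compounds, and the source may have more. Where it says the series, first, only, none or still open, it means among the compounds named here.

Compound 1 is `COc1cc(-c2cc(C(=O)O)c3ccccc3n2)ccc1OCC(=O)Nc1ccccc1`. In an ADME assay on HaCaT cells (Homo sapiens) for inhibition (on this read-out higher numbers stand for weaker inhibition and lower numbers for stronger inhibition), compound 1 gives only a limit of the assay, > 300000 nM. Compound 2 is `COc1cc(-c2cc(C(=O)O)c3ccccc3n2)ccc1OCC(=O)NCc1ccccc1`. In this assay compound 2 likewise gives only a limit, > 300000 nM. The step from compound 1 to compound 2 cannot be read from these two limits: a step that the two limits leave unreadable from compound 1 to compound 2. Compound 2 thus stands where every measured value of the series stands, namely at the limit of > 300000 nM in this assay, at which 2 of the 2 values shown sit.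

Compound 3 is `COc1cc(-c2cc(C(=O)O)c3ccccc3n2)ccc1OCC(=O)NCc1cccnc1`. It differs from compound 2 in one place: pyridin-3-yl in place of phenyl on a saturated chain carbon bound to an amide-type nitrogen. Within the data shown here, no measured step speaks to this exact change; the only measured step, from compound 1 to compound 2, is itself unreadable, so neither a size nor a direction can be taken from it. The expectation for compound 3 rests on that alone. The step from compound 2 to compound 3 is estimated as a step that the limit leaves unreadable from compound 2 to compound 3, that is, nothing beyond the scatter. Compound 3 is accordingly expected to give 400000 nM, with a range from 150000 nM to 1500000 nM, and most probably again only a limit rather than a number.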

Compound 3, half-maximal inhibitory concentration in the HaCaT assay: > 300000 nM
Compound 3 gave a limit, no number; the forecaster's own chance of this, stated with the estimate: 85%; the middle value does not contradict the limit.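

In the HaCaT assay compound 3 gives > 300000 nM, a limit of the assay and not a number. Compound 1, compound 2 and compound 3 all give only a limit in the HaCaT assay, so no new step can be read among them: the limit of > 300000 nM in the HaCaT assay, at which 3 of the 3 values shown sit.

In a physicochemical assay for lipophilicity, using the shake flask method, in phosphate buffer, measured as octanol-water partition, at pH 7.4 (a lower number here means a more polar compound, a higher number a more lipophilic compound), compound 2 gives 0.4 and compound 3 gives -0.8. The compounds shown leave open whether any change at the amide end yields a number in the HaCaT assay, and whether the shift in the physicochemical assay, a number 1.20 log units lower from compound 2 to compound 3 (beyond the scatter), bears on that read-out at all.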